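Ester chain length on the shared core

The compounds below may be only part of what the source reports. "The series", "measured", "known", "first", "only" and "open" are said of these compounds alone.

Three measured esters share one core and differ only in the alcohol part of the ester. Compound 1 `CCOC(=O)CCC(=O)N1CCN(CCCOc2cc3c(Nc4ccc(F)c(Cl)c4)ncnc3cc2OC)CC1` gives 70% in a functional assay on A549 cells (Homo sapiens) for cytotoxicity, read by MTT assay, with a stated time of 24 h, tested at 20 uM; a higher number here means a weaker effect of the compound at the concentration tested, a lower number a stronger effect. Compound 2 `CCCCCOC(=O)CCC(=O)N1CCN(CCCOc2cc3c(Nc4ccc(F)c(Cl)c4)ncnc3cc2OC)CC1` gives 81.2% in this assay, and compound 3 `CCCCCCCOC(=O)CCC(=O)N1CCN(CCCOc2cc3c(Nc4ccc(F)c(Cl)c4)ncnc3cc2OC)CC1` gives 79.9% in the same assay. Compound 3 thus holds the second highest of the three numbers; its nearest neighbour is compound 2, and the two lie within the scatter of each other, while even the furthest, compound 1, sits within the scatter of compound 3. Among the steps, only a number 11.2 percentage points higher from compound 1 to compound 2 (beyond the scatter) lies beyond the scatter; a number 9.9 percentage points higher from compound 1 to compound 3 (within the scatter) and a number 1.3 percentage points lower from compound 2 to compound 3 (within the scatter) both stay within it.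

Compound 4 `CCCCCCCCCCCCOC(=O)CCC(=O)N1CCN(CCCOc2cc3c(Nc4ccc(F)c(Cl)c4)ncnc3cc2OC)CC1` carries the change (pentyl in place of hydrogen on a saturated chain carbon, seven bonds along the chain from an oxygen next to a carbonyl group). Within the data shown here, the closest precedent is a number 1.3 percentage points lower from compound 2 to compound 3 (within the scatter), a lengthening of the same chain further out from the ester oxygen that stayed within the scatter; the larger step near the ester oxygen, a number 11.2 percentage points higher from compound 1 to compound 2 (beyond the scatter), is not the closer analogy. Compound 4 is therefore expected to show a number 0.1 percentage points higher from compound 3 to compound 4 (within the scatter), that is, no step beyond the scatter in this assay. Compound 4 is estimated at 80%, with a range from 66% to 92%.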

Compound 4, a percentage reported as activity, at one concentration (the size of the read-out at that concentration, not a potency): 86.8%
For compound 4 the middle estimate is 6.8 percentage points below the measured one, within the range that was stated.
By their numbers in this assay, from the lowest: compounds 1, 3, 2 and 4 (each within the scatter of the next, the first and the last beyond it).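

In this assay, the added pentyl seven bonds along the chain from the oxygen next to the carbonyl group gives a number 6.9 percentage points higher from compound 3 to compound 4 (within the scatter), and the heptyl five bonds along gives a number 5.6 percentage points higher from compound 2 to compound 4 (within the scatter), so compound 4 is not separated from either of these two esters and this far out along the chain the added carbons leave the read-out within the scatter. The new information lies at the ends of the series, where the decyl two bonds along gives a number 16.8 percentage points higher from compound 1 to compound 4 (beyond the scatter), a separation that compound 3 did not reach with a number 9.9 percentage points higher from compound 1 to compound 3 (within the scatter), although compound 2 did with a number 11.2 percentage points higher from compound 1 to compound 2 (beyond the scatter), so the set shows no steady climb with chain length and only compound 1 stands apart from compound 4. Nothing available gives a reason for these steps.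

Going by these compounds, whether a still longer chain on the ester oxygen would stay within the scatter of compound 4 remains open. Also open is whether an amine or a carboxylic acid at the far end of the chain would move the read-out, since every chain shown ends in a plain alkyl carbon.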